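Piperazine aryl swap toward compound 4

The source may report more compounds than this note shows. Statements on the series, on what has been measured and on what is new or still open speak of the compounds shown alone.

Three compounds of this series, sharing one core, have been run in a functional assay on CHO cells with adenosine receptor A1 (Homo sapiens) as the target, read by cAMP accumulation and immunoassay, with a stated time of 6 min, tested at 10 uM; on this read-out higher numbers stand for a weaker effect at the one concentration tested and lower numbers for a stronger effect. Compound 1 `Nc1scc(CN2CCN(c3cc(Cl)cc(Cl)c3)CC2)c1C(=O)c1ccc(Cl)cc1` gives -74%. Compound 2 `Nc1scc(CN2CCN(c3ccc(Cl)cc3F)CC2)c1C(=O)c1ccc(Cl)cc1` gives -81%. Compound 3 `Nc1scc(CN2CCN(c3cccnc3)CC2)c1C(=O)c1ccc(Cl)cc1` gives -23%. On these numbers compound 3 stands highest: the step of a number 51 percentage points higher from compound 1 to compound 3 (beyond the scatter) and the step of a number 58 percentage points higher from compound 2 to compound 3 (beyond the scatter) are both large and beyond the scatter, whereas the step of a number 7 percentage points lower from compound 1 to compound 2 (within the scatter) lies within it. Both carbon-only aromatic rings on the ring nitrogen therefore sit in the same strong region, and the pyridin-3-yl ring alone stands apart.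

The next compound, compound 4 `Nc1scc(CN2CCN(c3cccc(F)c3F)CC2)c1C(=O)c1ccc(Cl)cc1`, is not yet measured. It differs from compound 3 in one place: 2,3-difluorophenyl in place of pyridin-3-yl on an amine nitrogen in a ring. This reverses the kind of exchange seen in the two large steps, putting a carbon-only six-membered ring back where compounds 1 and 2 carry one. The two steps that bear on it, from compound 1 and from compound 2 to compound 3, were both large, so a large step in the opposite direction, toward a stronger effect, is expected in this assay.

The step from compound 3 to compound 4 is estimated as a number 47 percentage points lower from compound 3 to compound 4 (beyond the scatter). Compound 4 is accordingly estimated at -70%, within a range from -90% to -40%.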

Compound 4, a percentage reported as activity, at one concentration (the size of the read-out at that concentration, not a potency): -79%
Compound 4: the middle estimate sits 9 percentage points above what was measured; the measured number falls inside the stated range.
By their numbers in this assay, from the lowest: compounds 2, 4 and 1 (each within the scatter of the next); then compound 3.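

In this assay, the change to 2,3-difluorophenyl gives a number 56 percentage points lower from compound 3 to compound 4 (beyond the scatter) and so restores the strong region at this place on the ring nitrogen. Against the other two carbon-only rings, 2,3-difluorophenyl gives a number 2 percentage points higher from compound 2 to compound 4 (within the scatter) and 3,5-dichlorophenyl to 2,3-difluorophenyl gives a number 5 percentage points lower from compound 1 to compound 4 (within the scatter), so compounds 1, 2 and 4 cannot be told apart on this read-out even though compound 4 carries fluorine alone, compound 1 chlorine alone and compound 2 one of each. Among the four compounds, only compound 3 falls outside this group, and nothing available explains the large step.

Compound 3 differs from compounds 1, 2 and 4 both by its ring nitrogen and by carrying no halogen, so the compounds shown cannot say which of the two sets it apart; an unsubstituted phenyl ring and a chloropyridin-3-yl ring would separate these two readings. Going by these compounds, it also remains open whether the strong region extends to larger or non-halogen groups on the ring, such as methoxy or trifluoromethyl, and a single concentration gives no potency ranking within the group.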